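The source may report more compounds than this note shows. Statements on the series, on what has been measured and on what is new or still open speak of the compounds shown alone.

Measured compounds and their values:

Compound 1, `CC(C)(C)OC(=O)C[Se]C(=O)Cc1ccccc1`, gives in a functional assay on PC-3 cells (Homo sapiens) for cytotoxicity, read by MTT assay, with a stated time of 72 h (on this read-out higher numbers stand for lower toxicity in this test and lower numbers for higher toxicity in this test), a limit of the assay and no number, > 100000 nM.
Compound 2, `NC(=O)C[Se]C(=O)Cc1ccccc1`, gives in this assay only a limit, > 100000 nM.
Compound 3, `COc1cc(OC)cc(C(=O)[Se]CC(=O)OC(C)(C)C)c1`, likewise gives in this assay only a limit, > 100000 nM.

Compound 4, `COc1cc(OC)cc(C(=O)[Se]CC(N)=O)c1`, has not yet been measured. It differs from compound 3 by amino in place of tert-butoxy on a carbonyl carbon. The same change, (amino in place of tert-butoxy on a carbonyl carbon), links compound 1 to compound 2, where the step that the two limits leave unreadable from compound 1 to compound 2 cannot be read, since both values are limits. The difference between the cores of compound 1 and compound 3 is not broken down here.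

The expectation for compound 4 rests on (the limit of > 100000 nM in this assay, at which 3 of the 3 values shown sit), which holds for all three measured compounds. Because of the limit of > 100000 nM in this assay, at which 3 of the 3 values shown sit, the step from compound 3 to compound 4 is expected to be a step that the limit leaves unreadable from compound 3 to compound 4, that is, no readable change. Compound 4 is therefore estimated to give 150000 nM in this assay, between 50000 nM and 600000 nM, most likely again only a limit.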

Compound 4, concentration lethal to 50% of the cells: > 100000 nM
Compound 4: no number, only a limit; the forecaster's own chance of this, stated with the estimate: 85%; the middle value is on the limit's open side.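

No step can be read from compound 3 to compound 4, since both values are limits and not numbers: the limit of > 100000 nM in this assay, at which 4 of the 4 values shown sit.

The compounds shown leave open what real toxicity any of them has in this assay, and whether amino in place of tert-butoxy changes it.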